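Aryl Swap on the Amide Nitrogen: a Pyridinyl Analogue

This account rests on a few compounds, and the source may have more. Where it says the series, first, only, none or still open, it means among the compounds named here.

Two amides on a shared core have been tested in a functional assay on the whole organism (strain Wistar) for inhibition, with Rattus norvegicus as the target, read by paw edema, with a stated time of 24 h, at a dose of 100 mg/kg; on this read-out lower numbers stand for less inhibition and higher numbers for more inhibition at the one dose given (going by the name of the read-out). Compound 1 `COc1cc2c(cc1OC)C(CC(=O)Nc1cccc(Cl)c1)CC2` gives 63.3% in this assay. Compound 2 `COc1cc2c(cc1OC)C(CC(=O)Nc1ccccc1C)CC2` gives 23.3% in this assay. Within the data shown here, of the two numbers compound 2 stands lowest, and the one step leading to it, a number 40 percentage points lower from compound 1 to compound 2 (beyond the scatter), sets it well apart from compound 1, beyond the scatter.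

Compound 3 `COc1cc2c(cc1OC)C(CC(=O)Nc1cccnc1)CC2` has not been measured. It differs from compound 2 in one place: pyridin-3-yl in place of 2-methylphenyl on an amide-type nitrogen. Among the measured compounds shown here, the only measured step, a number 40 percentage points lower from compound 1 to compound 2 (beyond the scatter), concerns a different exchange at the same amide-type nitrogen, yet it shows that changing the aryl group there can shift the read-out by a large amount. For the measured compounds named here, no measured step involves pyridin-3-yl itself, so the direction for compound 3 rests on little. Since compound 2 sits at the low end, the expected step is a number 16.7 percentage points higher from compound 2 to compound 3 (beyond the scatter), upward but uncertain. On this basis compound 3 is estimated at 40%, with a range from 15% to 65%.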

Compound 3, a percentage reported as inhibition, in the whole organism at one dose (the size of the read-out at that dose, not a potency): 36.7%
For compound 3 the middle estimate is 3.3 percentage points above the measured one; low and high end bracket the measured number.
By their numbers in this assay, from the lowest: compound 2; then compound 3; then compound 1.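

With pyridin-3-yl on the amide-type nitrogen, this assay gives a number 13.4 percentage points higher from compound 2 to compound 3 (beyond the scatter) and a number 26.6 percentage points lower from compound 1 to compound 3 (beyond the scatter) on the other side, so the read-out at this position takes an intermediate level as well as the two far apart ones seen before. Among these compounds, this is the first group at this position whose aromatic ring holds a hetero atom and a hydrogen-bond acceptor, and the inhibition it gives stays clear of both carbocyclic neighbours, so the outcome here is not simply a matter of high or low. Nothing available accounts for this order among the three aryl groups.

Still open, from the compounds shown here alone, is how an unsubstituted phenyl, a benzyl group or a morpholine ring on the same nitrogen would read, and so whether the chlorine of the 3-chlorophenyl group or the methyl of the 2-methylphenyl group is what separates those two compounds. All three numbers also come from one dose and one stated time, which leaves the dose response of this series, and any change in its order at other doses, undefined.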